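The compounds below may be only part of what the source reports. "The series", "measured", "known", "first", "only" and "open" are said of these compounds alone.

Working notes on the series.

Among the compounds with values here, compound 1, `COc1ccc(Cn2cc3cc(C(=N)Nc4cccc(C(F)(F)F)c4)ncc3n2)cc1`, is the only member with a number in a functional assay on HT-1080 cells (Homo sapiens) for cytotoxicity, read by MTT assay, with a stated time of 72 h; a lower number here means a stronger inhibitor, a higher number a weaker inhibitor: compound 1 gives 13000 nM, a weak result. Compound 2, `Cn1cc2cc(C(=N)Nc3ccccc3)ncc2n1`, carries a methyl on the aromatic nitrogen and an unsubstituted phenyl on the amidine; in this assay compound 2 gives "not determined" (no result reported), so no value stands for it, and the step to compound 3 cannot be placed against a measured starting point.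

Compound 3, `COc1ccc(Cn2cc3cc(C(=N)Nc4ccccc4)ncc3n2)cc1`, is not yet measured. The change from compound 2 to compound 3 is 4-methoxyphenyl in place of hydrogen on a saturated chain carbon bound to an aromatic nitrogen; the same difference, cut one bond further out, reads methyl to 4-methoxybenzyl. Within the data shown here, no measured pair shows a step of this kind, so the direction and size of the step in this assay are not known from the data; nothing beyond the scatter is assumed.

Among the measured compounds shown here, the only anchor is compound 1 with 13000 nM, and on that basis compound 3 is expected to land near the weak end of the range as well. The estimate for compound 3 in this assay is 15000 nM, with a range from 5000 nM to 50000 nM, and a fair chance that only a limit is reported.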

Compound 3, half-maximal inhibitory concentration: 1130 nM
Compound 3: middle estimate off by 13-fold (1.12 log units), on the high side; the whole stated range lies above it.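

In this assay the single change of hydrogen in place of trifluoromethyl on an aromatic carbon, with the 4-methoxybenzyl group kept, gives a 12-fold lower number from compound 1 to compound 3 (1.06 log units; beyond the scatter), so this aromatic carbon is the first place in the series shown to matter in this assay, and the unsubstituted member, compound 3, is the stronger of the pair at 1130 nM. The step from compound 2 to compound 3 cannot be read, as compound 2 has no value, so the effect of methyl to 4-methoxybenzyl on the aromatic nitrogen remains without a measured size or direction. No measurement is at hand that bears on what lies behind the step from trifluoromethyl to hydrogen.

One pair cannot show whether hydrogen would also outperform a methoxy group, a fluorine atom or an amine on that aromatic carbon, or whether trifluoromethyl alone gives the weaker number. Also open, from the compounds shown here alone, is how the number would move if the 4-methoxybenzyl group gave way to a longer alkyl chain or a chain ending in a carboxylic acid.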